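This account rests on a few compounds, and the source may have more. Where it says the series, first, only, none or still open, it means among the compounds named here.

In a functional assay with Mus musculus as the target (a lower number here means a stronger inhibitor, a higher number a weaker inhibitor), compound 1 (`CCNC1CCCc2onc(O)c21`) gives 278000 nM. Compound 2 (`C=CCNC1CCCc2onc(O)c21`) is reported only as a limit, > 500000 nM. Compound 3 (`OCCNC1CCCc2onc(O)c21`) is also reported only as a limit, > 500000 nM, which places it at the limit of > 500000 nM in this assay, at which 2 of the 3 values shown sit. Compound 4 (`CN(C)C1CCCc2onc(O)c21`) carries dimethylamino in place of (2-hydroxyethyl)amino on a saturated ring carbon. For the measured compounds named here, two measured steps bear on this change, an at least 1.7-fold higher number from compound 1 to compound 2 (0.25 log units; that floor lies within the scatter) and an at least 1.7-fold higher number from compound 1 to compound 3 (0.25 log units; that floor lies within the scatter). Neither floor goes beyond the scatter, and neither step puts dimethylamino on the shared core. No shift beyond the scatter is therefore expected in this assay. The expected step is an at least 1.1-fold lower number from compound 3 to compound 4 (0.04 log units; that floor lies within the scatter). For compound 4 the estimated value is 450000 nM, within an expected range of 170000 nM to 1200000 nM.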

Compound 4, half-maximal inhibitory concentration: > 500000 nM
Compound 4: only a limit was reported; the forecaster's own chance of this, stated with the estimate: 55%; middle value at least 1.1-fold (0.04 log units) away from the limit.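

In this assay, compound 4 is reported only as a limit, > 500000 nM, so dimethylamino on this saturated ring carbon yields no measured number. Against ethylamino the result is an at least 1.7-fold higher number from compound 1 to compound 4 (0.25 log units; that floor lies within the scatter), so the change is not shown to go beyond the scatter. The steps from compound 2 and compound 3 to compound 4 cannot be read, and compound 1 alone remains below the shared limit: the limit of > 500000 nM in this assay, at which 3 of the 4 values shown sit.

As far as these compounds go, it remains open how far compounds 2, 3 and 4 actually lie from compound 1. Also open, from the compounds shown here alone, is whether an unsubstituted amine or a longer chain such as butylamino at this place would give a measured value.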